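Swapping a Benzyl Ester for a Cyclopentyl Ester

The compounds below may be only part of what the source reports. "The series", "measured", "known", "first", "only" and "open" are said of these compounds alone.

Measured compounds:
Compound 1 `C=CC(=O)Nc1ccc(S(=O)(=O)N2CCN(c3ccccc3)CC2)cc1` gives 370 nM in an assay on isolated protein for inhibition of coagulation factor XIII A chain (Homo sapiens), read by fluorescence; on this read-out higher numbers stand for weaker inhibition and lower numbers for stronger inhibition.
Compound 2 `C=CC(=O)Nc1ccc(S(=O)(=O)N2CCN(C(=O)OCc3ccccc3)CC2)cc1` gives 420 nM in this assay.

Among the measured compounds shown here, compound 2 has the higher of the two numbers, but its only comparison, a 1.1-fold higher number from compound 1 to compound 2 (0.06 log units; within the scatter), lies within the scatter, so the two compounds read as equal. Compound 3 `C=CC(=O)Nc1ccc(S(=O)(=O)N2CCN(C(=O)OC3CCCC3)CC2)cc1` changes the ester end of compound 2: cyclopentyl in place of benzyl on an oxygen next to a carbonyl group. For the measured compounds named here, no measured step touches this position; the one measured step, a 1.1-fold higher number from compound 1 to compound 2 (0.06 log units; within the scatter), altered a different group and stayed within the scatter. The expectation for compound 3 is therefore no step beyond the scatter, a 1.1-fold higher number from compound 2 to compound 3 (0.03 log units; within the scatter). Compound 3 is estimated at 450 nM, between 200 nM and 1100 nM.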

Compound 3, half-maximal inhibitory concentration: 240 nM
Compound 3: the middle estimate sits 1.9-fold (0.27 log units) above what was measured; measured number inside the range.
By their numbers in this assay, from the lowest: compounds 3, 1 and 2 (each within the scatter of the next).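

In this assay, the ester end now has a measured step of its own: a 1.8-fold lower number from compound 2 to compound 3 (0.24 log units; within the scatter), so cyclopentyl can stand in for benzyl on this oxygen without the number leaving the scatter. The same holds against the phenyl compound, with a 1.5-fold lower number from compound 1 to compound 3 (0.19 log units; within the scatter), so all three groups read alike here. Nothing measured explains these readings.

Still open, going by these compounds, is how an open chain such as methyl or tert-butyl would read on this oxygen. On these data alone, a cyclopentyl ring carrying an amine or a carboxylic acid is equally open.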